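The source may hold more compounds than are shown below. What is called first, only, known or untested is meant among the compounds shown, and "the series" means these compounds.

Values in a functional assay on HeLa cells (Homo sapiens) for antiproliferative activity, read by MTT assay, with a stated time of 48 h (on this read-out lower numbers stand for stronger inhibition and higher numbers for weaker inhibition), follow.
- compound 1 `CCN(CC)CCn1c(N)c(-c2nc3ccccc3[nH]2)c2nc(C#N)c(C#N)nc21` gives 11600 nM
- compound 2 `CCN(CC)CCCCn1c(N)c(-c2nc3ccccc3[nH]2)c2nc(C#N)c(C#N)nc21` gives 10100 nM
- compound 3 `CCN(CC)CCn1c(N)c(-c2nc3ccccc3n2C)c2nc(C#N)c(C#N)nc21` gives > 50000 nM (a limit, not a number)

Compound 3 gives no number, only a limit (the limit of > 50000 nM in this assay, at which 1 of the 3 values shown sits). Compound 4 `CCN(CC)CCCn1c(N)c(-c2nc3ccccc3n2C)c2nc(C#N)c(C#N)nc21` differs from it in one place ((diethylamino)methyl in place of diethylamino on a saturated chain carbon, two bonds along the chain from an aromatic nitrogen): (diethylamino)methyl in place of diethylamino on a saturated chain carbon, two bonds along the chain from an aromatic nitrogen. Cut one bond further out, this reads 2-(diethylamino)ethyl to 3-(diethylamino)propyl.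

The measured chain change stayed within the scatter (a 1.1-fold lower number from compound 1 to compound 2 (0.06 log units; within the scatter)). Methyl in place of hydrogen on an aromatic nitrogen gave a larger step (an at least 4.3-fold higher number from compound 1 to compound 3 (0.63 log units; beyond the scatter)), and compound 4 keeps that methyl. On the chain step (a 1.1-fold lower number from compound 1 to compound 2 (0.06 log units; within the scatter)), no change beyond the scatter is expected in this assay here. The expected step is small (a number no higher from compound 3 to compound 4 (the limit leaves the size open)). Compound 4 is estimated at 50000 nM (range 22000 nM to 100000 nM).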

Compound 4, half-maximal inhibitory concentration: 12400 nM
The estimate for compound 4 lay 4.0-fold (0.61 log units) above the measured number; the measured number lies below the stated range.
By their numbers in this assay, from the lowest: compounds 2, 1 and 4 (each within the scatter of the next). At a limit, above all of these: compound 3.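

Compound 3 stands at a limit, not a number: the limit of > 50000 nM in this assay, at which 1 of the 4 values shown sits.

Even so, the step from diethylamino to (diethylamino)methyl at this saturated chain carbon is not silent on the methylated compounds, showing an at least 4.0-fold lower number from compound 3 to compound 4 (0.60 log units; beyond the scatter). The earlier chain step, with hydrogen on the aromatic nitrogen, gave only a 1.1-fold lower number from compound 1 to compound 2 (0.06 log units; within the scatter), so chain length matters in one pair and not in the other.

On these data alone, the true size of the new step stays open. Also open, as far as these compounds go, are a 3-(diethylamino)propyl chain with hydrogen on the aromatic nitrogen, a longer chain on the methylated compounds, and a cyclic amine such as morpholine in place of diethylamino.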